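Nitro Placement on the Benzyl Arm of an Oxadiazolone

The compounds below may be only part of what the source reports. "The series", "measured", "known", "first", "only" and "open" are said of these compounds alone.

Compound 1 `COc1nn(Cc2ccccc2)c(=O)o1` is the parent of this small set. In an assay on COS-7 cells for inhibition of Fatty-acid amide hydrolase 1 (Homo sapiens), read by scintillation counting, with a stated time of 10 min, tested at 10 uM (a lower number here means less inhibition, a higher number more inhibition at the concentration tested (going by the name of the read-out)), compound 1 is reported as "not active" (no number reported), so no single number is available for it. Compound 2 `COc1nn(Cc2ccccc2[N+](=O)[O-])c(=O)o1`, carrying a nitro group, reaches 36% in this assay. Compound 3 `COc1nn(Cc2cccc([N+](=O)[O-])c2)c(=O)o1` is the untested member; its change from compound 1 is nitro in place of hydrogen on an aromatic carbon. Given the shift seen between compound 1 and compound 2, a rise in this assay beyond the scatter is expected, though no step is known for compound 3 itself. Compound 3 is therefore estimated at 25%, in the range 5% to 50%.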

Compound 3, a percentage reported as inhibition, at one concentration (the size of the read-out at that concentration, not a potency): 7%
Beside the measured number, compound 3's estimate is 18 percentage points above it; the range from low to high includes it.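

Among the compounds shown here, compound 1 is reported as "not active" (no number reported) in this assay, so no step from it to compound 3 can be read. Going by these compounds, how far nitro in place of hydrogen shifts inhibition stays open, and no evidence bears on this result.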